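Swapping a Methyl for a Chloro on Compound 2

This account rests on a few compounds, and the source may have more. Where it says the series, first, only, none or still open, it means among the compounds named here.

Of the compounds shown here, two have been measured so far in an ADME assay on microsomes from liver (Rattus norvegicus) for metabolic stability, with a stated time of 10 min, tested at 1 uM; on this read-out higher numbers stand for a more stable compound and lower numbers for a less stable compound. Compound 2 `Cc1cc(C(F)(F)F)ccc1-c1ccc2nn([C@@H](CC(C)C)c3ccc(C(=O)NCCC(=O)O)cc3)cc2c1C` stands highest of the two at 107%, while compound 1 `COc1c(-c2ccc(C(F)(F)F)cc2Cl)ccc2nn([C@@H](CC(C)C)c3ccc(C(=O)NCCC(=O)O)cc3)cc12` gives 84%, a gap beyond the usual scatter. Compound 3 `Cc1c(-c2ccc(C(F)(F)F)cc2Cl)ccc2nn([C@@H](CC(C)C)c3ccc(C(=O)NCCC(=O)O)cc3)cc12` has not yet been measured. It differs from compound 2 by a single change chloro in place of methyl on an aromatic carbon, which turns 2-methyl-4-(trifluoromethyl)phenyl into 2-chloro-4-(trifluoromethyl)phenyl. Within the data shown here, no measured pair shows this change on its own, so its size cannot be read directly. With compound 1 at 84% as the only lower reference, a small drop in this assay, probably within the scatter, is the expected outcome. The expected change is a number 9 percentage points lower from compound 2 to compound 3 (within the scatter). Compound 3 is estimated at 98%, with a range from 82% to 112%.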

Compound 3, percent of the compound remaining: 107%
Compound 3: middle estimate off by 9 percentage points, on the low side; the measured number falls inside the stated range.
By their numbers in this assay, from the lowest: compound 1; then compounds 2 and 3 (each within the scatter of the next).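

In this assay, chloro in place of methyl on the aromatic carbon ortho to a large group gives no change at the digits printed from compound 2 to compound 3 (within the scatter), so this single change has no measurable effect on the number at this position. Among these compounds, a second single change, methyl in place of methoxy on an aromatic carbon, gives a number 23 percentage points higher from compound 1 to compound 3 (beyond the scatter), the first step in this set that can be read on its own and lies beyond the scatter. Nothing measured here explains either step.

Still open, from the compounds shown here alone, is whether a fluoro or a nitrile in place of the chloro would also leave the number unchanged. Going by these compounds, it is equally open whether an ethyl or an amine in place of the methyl that replaced methoxy would keep the higher number.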